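The compounds below may be only part of what the source reports. "The series", "measured", "known", "first", "only" and "open" are said of these compounds alone.

In a toxicity assay on cells (Epithelial cell, Homo sapiens) for cytotoxicity, read by MTT assay, with a stated time of 72 h (a higher number here means a weaker inhibitor, a lower number a stronger inhibitor), compound 3 `C=CC(=O)N1CCC(Oc2nc(Nc3cnn(C)c3)nc3ccsc23)CC1` gives > 20000 nM, which is a limit of the assay and not a number. Compound 1 `C=CC(=O)N1CCC(Oc2nc(Nc3ccc(N(C)CCN(C)C)cc3OC)nc3[nH]ccc23)CC1` gives > 20000 nM, also a limit. Compound 2 `C=CC(=O)N1CCC(Oc2nc(Nc3ccc(N4CCN(C)CC4)cc3OC)nc3[nH]ccc23)CC1` gives > 20000 nM, again a limit. All the readings so far therefore come down to one thing: the limit of > 20000 nM in this assay, at which 3 of the 3 values shown sit.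

Compound 4 `C=CC(=O)N1CCC(Oc2nc(Nc3ccn(C)n3)nc3ccsc23)CC1` keeps the atoms of compound 3 but joins them differently: 1-methyl-1H-pyrazol-3-yl in place of 1-methyl-1H-pyrazol-4-yl on a nitrogen on an aromatic ring. In words, 1-methyl-1H-pyrazol-3-yl stands in place of 1-methyl-1H-pyrazol-4-yl on a nitrogen on an aromatic ring.

Among the compounds with values here, the only measured step is a step that the two limits leave unreadable from compound 1 to compound 2. Within the data shown here, it concerns other groups and offers no size to carry over, so no measured step bears on this swap. No change beyond the scatter is therefore expected in this assay, and no direction can be named. The expected step is a number no higher from compound 3 to compound 4 (the limit leaves the size open). The expectation rests on compound 3, whose limit is > 20000 nM. Compound 4 is estimated at 20000 nM, with an expected range from 8000 nM to 40000 nM, and the assay will most likely report only a limit again.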

Compound 4, half-maximal inhibitory concentration: > 20000 nM
Compound 4: a limit, no number; the forecaster's own chance of this, stated with the estimate: 85%; the middle value sits exactly at the limit.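

Compound 3 and compound 4 both give only a limit and not a number in this assay, so no step can be read between them, and the same holds for compound 1 and compound 2: the limit of > 20000 nM in this assay, at which 4 of the 4 values shown sit.

Whether 1-methyl-1H-pyrazol-3-yl in place of 1-methyl-1H-pyrazol-4-yl changes cytotoxicity at all stays open, as does the concentration at which any of these compounds would reach a half-maximal effect.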